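Swapping a Cyclohexyl Ring for an Open Ether Chain

The compounds below may be only part of what the source reports. "The series", "measured", "known", "first", "only" and "open" are said of these compounds alone.

Measured compounds:
Compound 1 `COc1cccc(-n2cc3nc(-c4cccnc4C)n(C[C@H]4CCCN(CC5CCCCC5)C4)c(=O)c3n2)c1`: 200 nM in an assay on HEK293 cells for displacement of a labelled ligand from growth hormone secretagogue receptor type 1 (Homo sapiens), with a stated time of 60 min; on this read-out lower numbers stand for stronger inhibition and higher numbers for weaker inhibition
Compound 2 `COc1cccc(-n2cc3nc(-c4cccnc4C)n(C[C@H]4CCCN(CC5CCCCO5)C4)c(=O)c3n2)c1`: 120 nM

Among the measured compounds shown here, compound 1 stands highest of the two measured numbers, and the only recorded step, a 1.7-fold lower number from compound 1 to compound 2 (0.22 log units; within the scatter), stays within the scatter. Compound 3 `CCO[C@H](C)CN1CCC[C@H](Cn2c(-c3cccnc3C)nc3cn(-c4cccc(OC)c4)nc3c2=O)C1` differs from compound 1 in one place: 1-ethoxyethyl in place of cyclohexyl on a saturated chain carbon bound to an amine nitrogen in a ring. The step to compound 2 bears directly on this, since oxan-2-yl likewise introduces one oxygen acceptor on the saturated chain carbon bound to the amine nitrogen in a ring, and that change moved the number only a little. For the measured compounds named here, compound 3 goes further by having no ring at all, and no measured pair shows what that alone does. For compound 3 the expectation is therefore a step no larger than the scatter, a 1.1-fold lower number from compound 1 to compound 3 (0.05 log units; within the scatter). The estimated value for compound 3 is 180 nM, with a range from 70 nM to 450 nM.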

Compound 3, half-maximal inhibitory concentration: 40 nM
The estimate for compound 3 lay 4.5-fold (0.65 log units) above the measured number; the measured number lies below the stated range.
By their numbers in this assay, from the lowest: compound 3; then compounds 2 and 1 (each within the scatter of the next).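

In this assay, replacing cyclohexyl with 1-ethoxyethyl gives a 5.0-fold lower number from compound 1 to compound 3 (0.70 log units; beyond the scatter) and so shows that a change on the saturated chain carbon bound to an amine nitrogen in a ring can move the number beyond the scatter, which the earlier step did not do. Oxan-2-yl also carries an oxygen, yet putting 1-ethoxyethyl in its place gives a 3.0-fold lower number from compound 2 to compound 3 (0.48 log units; beyond the scatter) and shows that these two oxygen-bearing groups are not equivalent at this position. No measurement available here explains why the open chain gives the lowest number.

A plain pentyl chain, with carbon in place of the oxygen, would help separate the effect of losing the ring from that of adding the oxygen. Also open, on these data alone, are the opposite stereocentre of 1-ethoxyethyl and the outcome with a shorter methoxy or longer propoxy end on the chain.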